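This account rests on a few compounds, and the source may have more. Where it says the series, first, only, none or still open, it means among the compounds named here.

Measured in a functional assay on PC-3 cells (Homo sapiens) for antiproliferative activity, read by sulforhodamine B assay; on this read-out higher numbers stand for weaker inhibition of growth and lower numbers for stronger inhibition of growth:
- compound 1 `CC(C)CCCOc1cccc(O)c1C(=O)/C=C/c1ccc(O)cc1`: 3600 nM
- compound 2 `CC(C)(C)CCOc1cccc(O)c1C(=O)/C=C/c1ccc(O)cc1`: 3220 nM

Compound 2 stands level with compound 1, within the scatter. Compound 3 `O=C(/C=C/c1ccc(O)cc1)c1c(O)cccc1OCCC1CCCCC1` differs from compound 2 as follows: cyclohexyl in place of tert-butyl on a saturated chain carbon, two bonds along the chain from an oxygen on an aromatic ring. Going by the values given here, one measured step bears on this change at the same place, a 1.1-fold lower number from compound 1 to compound 2 (0.05 log units; within the scatter). It stays within the scatter, but no chain carrying a ring has been measured, so that support is thin. No step beyond the scatter is therefore expected in this assay. The expected step is a 1.1-fold lower number from compound 2 to compound 3 (0.03 log units; within the scatter). For compound 3 the estimated value is 3000 nM, with an expected range of 1200 nM to 7500 nM.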

Compound 3, concentration for 50% growth inhibition: > 30000 nM
Compound 3 gave a limit, no number (the forecaster's own chance of this, stated with the estimate: 3%); at least 10-fold (1.00 log units) between middle value and limit.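

Compound 3 gives no number in this assay, only a limit: the limit of > 30000 nM in this assay, at which 1 of the 3 values shown sits. Compounds 1 and 2 had suggested that this place tolerates a change of group, but the ring-bearing chain shows otherwise: cyclohexyl in place of tert-butyl gives an at least 9.3-fold higher number from compound 2 to compound 3 (0.96 log units; beyond the scatter). Cyclohexyl in place of isobutyl gives an at least 8.3-fold higher number from compound 1 to compound 3 (0.92 log units; beyond the scatter).

The compounds shown leave open whether this step goes with the ring itself or with the added carbons. Cyclopentyl, phenyl or a longer open chain at the same place would separate the two.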